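Adding a Butyl Group to Compound 2

The compounds below may be only part of what the source reports. "The series", "measured", "known", "first", "only" and "open" are said of these compounds alone.

Compound 1 `CN1CCN(C(=O)/C=C/c2cccc(C(F)(F)F)c2)CC1`: > 100 mg/kg (a limit)
Compound 2 `O=C1CCC(O)(c2cccc(C(F)(F)F)c2)N1`: > 200 mg/kg (a limit)
Compound 3 `CN1C(=O)CCC1(O)c1ccc(C(F)(F)F)cc1`: > 200 mg/kg (a limit)

All three compounds were tested in a functional assay on the whole organism with Mus musculus as the target; on this read-out lower numbers stand for an effect already at smaller amounts and higher numbers for an effect only at larger amounts of compound. None of them gave an exact number, so nothing yet shows how strongly any of them acts.

Compound 2 gives > 200 mg/kg, which is a limit and not a measured dose. This is the limit of > 200 mg/kg in this assay, at which 2 of the 3 values shown sit.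

Compound 4 `CCCCN1C(=O)CCC1(O)c1cccc(C(F)(F)F)c1` has not been measured yet. It differs from compound 2 in one place: butyl in place of hydrogen on an amide-type nitrogen in a ring. Among the compounds with values here, no two measured compounds differ in just one place, so no measured step can guide the size of this change. Any forecast is therefore a cautious one.

Compound 2 at > 200 mg/kg offers only a limit as a starting point for that forecast. The expected change is modest and towards a lower dose: an at least 1.3-fold lower number from compound 2 to compound 4 (0.12 log units; that floor lies within the scatter) is an estimated step, and it could well fall within the usual scatter. Another limit in this assay is also quite possible.

For compound 4 the estimated value is 150 mg/kg, with an expected range from 60 mg/kg to 350 mg/kg.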

Compound 4, dose for half-maximal effect: > 200 mg/kg
Compound 4 ended at the assay's limit; the forecaster's own chance of this, stated with the estimate: 55%; middle value at least 1.3-fold (0.12 log units) away from the limit.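

In this assay compound 4 gives > 200 mg/kg, which is a limit and not a measured dose. Within the data shown here, compound 2 also has only a limit, so no step from compound 2 to compound 4 can be read. The compounds shown leave open at what dose either compound acts, and whether the butyl group changes that dose at all.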